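Triazole aryl variation followed in the cytotoxicity series

The source may hold more compounds than are shown below. What is called first, only, known or untested is meant among the compounds shown, and "the series" means these compounds.

Of the compounds shown here, two of the shared core have been measured. Compound 1 `Cc1c(C(=O)Nc2ccc(Oc3ccnc4[nH]ccc34)cc2)nnn1-c1ccccc1F` carries a 2-fluorophenyl on an aromatic nitrogen, and in a functional assay on MCF7 cells (Homo sapiens) for cytotoxicity, read by MTT assay, with a stated time of 72 h (on this read-out higher numbers stand for weaker inhibition and lower numbers for stronger inhibition), compound 1 gives 280 nM. Compound 2 `Cc1c(C(=O)Nc2ccc(Oc3ccnc4[nH]ccc34)cc2)nnn1-c1ccc(F)cc1` carries a 4-fluorophenyl on that nitrogen, and in this assay compound 2 gives 390 nM. Going by the values given here, the only step recorded so far, a 1.4-fold higher number from compound 1 to compound 2 (0.14 log units; within the scatter), leaves the two values indistinguishable; compound 2 therefore stands at the higher of the two numbers, with compound 1 within the scatter of it.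

Compound 3 `Cc1c(C(=O)Nc2ccc(Oc3ccnc4[nH]ccc34)cc2)nnn1-c1ccc(Cl)c(C(F)(F)F)c1` alters the group on the same nitrogen: 4-chloro-3-(trifluoromethyl)phenyl in place of 4-fluorophenyl on an aromatic nitrogen. Among the compounds with values here, no measured pair contains a chloro or a trifluoromethyl group, so the single step that touches this position, a 1.4-fold higher number from compound 1 to compound 2 (0.14 log units; within the scatter), shows only that moving one fluorine around this ring did not shift this assay beyond the scatter. The entering group is not covered by any measured pair, and no direction can be read from the data. Compound 3 is expected to give 300 nM in this assay, between 80 nM and 1200 nM, corresponding to an expected step of a 1.3-fold lower number from compound 2 to compound 3 (0.11 log units; within the scatter).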

Compound 3, half-maximal inhibitory concentration: 8410 nM
For compound 3 the middle estimate is 28-fold (1.45 log units) below the measured one, and the stated range ends below it.
By their numbers in this assay, from the lowest: compounds 1 and 2 (each within the scatter of the next); then compound 3.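

The group on the aromatic nitrogen is not indifferent in this assay: moving one fluorine around the ring stayed within the scatter, but the larger replacement gives a 22-fold higher number from compound 2 to compound 3 (1.33 log units; beyond the scatter) and a 30-fold higher number from compound 1 to compound 3 (1.48 log units; beyond the scatter). The position therefore responds to the substitution on this phenyl ring, and the response to 4-chloro-3-(trifluoromethyl)phenyl is toward weaker inhibition, with the six-membered aromatic ring of carbon itself unchanged across all three compounds. Chloro and trifluoromethyl enter together, so these steps do not divide the loss between them, and no measurement at hand accounts for it.

Open, going by these compounds, is whether chloro alone or trifluoromethyl alone on this phenyl ring carries the step, and whether an unsubstituted phenyl, a methoxy group or an amine on the ring would stay close to compound 1 at 280 nM. Also open, on these data alone, is how the series would respond if a saturated alkyl chain or a group bearing a carboxylic acid took the place of the phenyl ring on this nitrogen.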